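From 4-phenylphenyl to 4-(tert-butyl)phenyl: working notes

This account rests on a few compounds, and the source may have more. Where it says the series, first, only, none or still open, it means among the compounds named here.

In a functional assay on BGC-823 cells (Homo sapiens) for inhibition, read by MTT assay, with a stated time of 72 h (on this read-out lower numbers stand for stronger inhibition and higher numbers for weaker inhibition), compound 1 (`O=C1/C(=C\c2ccccc2)c2c(ncn2COCc2ccccc2)CCN1Cc1ccccc1`) stands lowest at 20400 nM among the three measured compounds. Compound 2 (`O=C1/C(=C\c2ccccc2)c2c(ncn2COCc2ccccc2)CCN1Cc1ccc(-c2ccccc2)cc1`) gives 81000 nM and compound 3 (`COc1ccc(CN2CCc3ncn(COCc4ccccc4)c3/C(=C/c3ccccc3)C2=O)cc1`) gives 71600 nM within the scatter of each other. Two modest steps lead up to this level: a 4.0-fold higher number from compound 1 to compound 2 (0.60 log units; beyond the scatter) and a 3.5-fold higher number from compound 1 to compound 3 (0.55 log units; beyond the scatter) in the same assay.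

Compound 4 (`CC(C)(C)c1ccc(CN2CCc3ncn(COCc4ccccc4)c3/C(=C/c3ccccc3)C2=O)cc1`) has tert-butyl in place of phenyl on an aromatic carbon . Since a 1.1-fold lower number from compound 2 to compound 3 (0.05 log units; within the scatter) at this same place stays within the scatter, no step beyond the scatter is expected in this assay here. The expected change is a 1.2-fold lower number from compound 2 to compound 4 (0.10 log units; within the scatter) by this estimate. For compound 4 the estimated value is 65000 nM with an expected range from 28000 nM to 130000 nM in this series.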

Compound 4, half-maximal inhibitory concentration: 27800 nM
Compound 4: middle estimate off by 2.3-fold (0.37 log units), on the high side, and the stated range ends above it.
By their numbers in this assay, from the lowest: compounds 1 and 4 (each within the scatter of the next); then compounds 3 and 2 (each within the scatter of the next).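

Tert-butyl at this position gives a 2.9-fold lower number from compound 2 to compound 4 (0.46 log units; beyond the scatter) and a 2.6-fold lower number from compound 3 to compound 4 (0.41 log units; beyond the scatter) in this assay while the earlier exchange of methoxy for phenyl here stayed within the scatter, so the identity of the group does matter at this place. Against the unsubstituted compound the change reads a 1.4-fold higher number from compound 1 to compound 4 (0.13 log units; within the scatter) so substitution here is not tied to higher numbers in every case, compounds 2 and 3 being the ones that show them. Nothing available explains why tert-butyl parts from phenyl and methoxy here.

As far as these compounds go, whether an amine or a carboxylic acid at this position would follow tert-butyl or phenyl remains open. So does the outcome for a longer alkyl chain.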